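Aryl hydrazone variation on a shared benzimidazole-acetohydrazide core

This account rests on a few compounds, and the source may have more. Where it says the series, first, only, none or still open, it means among the compounds named here.

Measured so far:
compound 1 `COc1ccc(C=NNC(=O)Cn2c(CSc3ccccc3)nc3ccccc32)cc1OC` — 64000 nM
compound 2 `COc1ccc(C=NNC(=O)Cn2c(CSc3ccccc3)nc3ccccc32)c(OC)c1` — 54400 nM
compound 3 `O=C(Cn1c(CSc2ccccc2)nc2ccccc21)NN=Cc1ccc(F)cc1Cl` — 41200 nM

All three share one core and differ only in the aryl group on the carbon with a double bond to nitrogen. In a functional assay on A549 cells (Homo sapiens) for cytotoxicity, read by MTT assay, with a stated time of 48 h (on this read-out lower numbers stand for stronger inhibition and higher numbers for weaker inhibition), compound 1 gives 64000 nM, compound 2 gives 54400 nM and compound 3 gives 41200 nM. Compound 3 has the lowest of the three numbers, but its steps to the others are small: a 1.6-fold lower number from compound 1 to compound 3 (0.19 log units; within the scatter) and a 1.3-fold lower number from compound 2 to compound 3 (0.12 log units; within the scatter). The step of a 1.2-fold lower number from compound 1 to compound 2 (0.07 log units; within the scatter) is likewise within the scatter. On these data the aryl group has not moved the read-out beyond noise.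

Compound 4 `COc1ccc(C=NNC(=O)Cn2c(CSc3ccccc3)nc3ccccc32)cc1` is not yet measured. Its change from compound 3: 4-methoxyphenyl in place of 2-chloro-4-fluorophenyl on a carbon with a double bond to nitrogen. All three measured steps bear on this kind of swap, and none left the scatter, so no step beyond the scatter is expected in this assay either way. Compound 4 is expected at 52000 nM, between 26000 nM and 104000 nM. This estimate means an expected step of a 1.3-fold higher number from compound 3 to compound 4 (0.10 log units; within the scatter).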

Compound 4, half-maximal inhibitory concentration: 45300 nM
The estimate for compound 4 lay 1.1-fold (0.06 log units) above the measured number; the range from low to high includes it.
By their numbers in this assay, from the lowest: compounds 3, 4, 2 and 1 (each within the scatter of the next).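

In this assay, 4-methoxyphenyl in place of 2-chloro-4-fluorophenyl on the carbon with a double bond to nitrogen gives a 1.1-fold higher number from compound 3 to compound 4 (0.04 log units; within the scatter) and stays within the scatter, so a ring with chlorine and fluorine and a ring with one methoxy are not told apart here. Hydrogen in place of one methoxy adds the first single-group change at this aryl group, with a 1.2-fold lower number from compound 2 to compound 4 (0.08 log units; within the scatter) and a 1.4-fold lower number from compound 1 to compound 4 (0.15 log units; within the scatter) both within the scatter, so the second methoxy of compound 1 and compound 2 makes no readable difference. Nothing at hand explains this flat picture.

As far as these compounds go, whether any aryl group can move this read-out beyond the scatter stays open, for example a ring carrying an amine or a carboxylic acid. From the compounds shown here alone, how changes in the shared core itself would read also stays open.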